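Series Notes: Benzyl for Cyclohexyl at Compound 3

The source may report more compounds than this note shows. Statements on the series, on what has been measured and on what is new or still open speak of the compounds shown alone.

Measured compounds:
compound 1 `COc1ccccc1-c1cn2ccnc2c(-c2ccc3ncn(C4CCCCC4)c3c2)n1`: 14.6%
compound 2 `c1cn2cc(-c3ccc4c(c3)ncn4C3CCCCC3)nc(-c3ccc4ncn(C5CCCCC5)c4c3)c2n1`: 30%

Both numbers come from a functional assay on HL-60 cells (Homo sapiens) for inhibition, read by sulforhodamine B assay, with a stated time of 48 h, tested at 10 uM; a higher number here means more inhibition at the concentration tested (going by the name of the read-out), a lower number less inhibition. Compound 2 stands highest of the two; the gap down to compound 1 is beyond the usual scatter. Compound 3 `c1ccc(Cn2cnc3ccc(-c4nc(-c5ccc6c(c5)ncn6C5CCCCC5)cn5ccnc45)cc32)cc1` differs from compound 2 by benzyl in place of cyclohexyl on an aromatic nitrogen. No step between measured compounds covers such a change, so nothing shown sets its size. In this assay the expectation is a shift of no more than the scatter, in no fixed direction. Compound 3 is expected to give 30%, with a range from 12% to 52%. This estimate means a step of no change at the digits printed from compound 2 to compound 3 (within the scatter), expected to stay within the scatter.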

Compound 3, a percentage reported as inhibition, at one concentration (the size of the read-out at that concentration, not a potency): -20.8%
Estimate against measurement, compound 3: 50.8 percentage points above, outside the stated range (below it).
By their numbers in this assay, from the lowest: compound 3; then compound 1; then compound 2.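

Notes on this nitrogen: in this assay, benzyl in place of cyclohexyl gives a number 50.8 percentage points lower from compound 2 to compound 3 (beyond the scatter) on the aromatic nitrogen, so this position is sensitive to the change of group, which compounds 1 and 2 alone could not show. Compound 3 reads -20.8% and so falls on the negative side of zero, with the other cyclohexyl kept. Nothing available bears on why the step is this large.

Still open, as far as these compounds go, is whether the aromatic ring or the extra carbon carries the step. Phenyl, phenethyl or a piperidine on this nitrogen would each read differently on that question.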